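Adding a Fluorine Next Door to the Amide

The compounds below may be only part of what the source reports. "The series", "measured", "known", "first", "only" and "open" are said of these compounds alone.

Measured compounds:
Compound 1, `O=C(Nc1ccccc1F)c1cccc2[nH]c(-c3ccccn3)nc12`: 54.7 uM
Compound 2, `O=C(Nc1ccccc1)c1cccc2[nH]c(-c3ccncc3)nc12`: 49.8 uM

For the measured compounds named here, both compounds share one core and differ in two places, so no single step connects them. In an ADME assay on Vero cells (Chlorocebus sabaeus) for cytotoxicity (on this read-out lower numbers stand for higher toxicity in this test and higher numbers for lower toxicity in this test), compound 1 gives 54.7 uM, and in this assay compound 2 gives 49.8 uM. The two numbers lie within the scatter of each other, so compound 2 stands side by side with compound 1, with no difference that can be read as real.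

Compound 3, `O=C(Nc1ccccc1F)c1cccc2[nH]c(-c3ccncc3)nc12`, has not yet been measured in this assay. It differs from compound 2 in one place: fluoro in place of hydrogen on an aromatic carbon. Compound 1 already carries this fluoro group, and its value in this assay does not set it apart from compound 2. On that basis no step beyond the scatter is expected from compound 2 to compound 3; the estimated step is a 1.0-fold higher number from compound 2 to compound 3 (0.00 log units; within the scatter). Compound 3 is therefore expected to give about 50 uM in this assay, with a range from 25 uM to 100 uM.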

Compound 3, half-maximal toxic concentration: 111 uM
Compound 3: middle estimate off by 2.2-fold (0.35 log units), on the low side; the whole stated range lies below it.
By their numbers in this assay, from the lowest: compounds 2 and 1 (each within the scatter of the next); then compound 3.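

With pyridin-4-yl held in place, changing phenyl to 2-fluorophenyl gives a 2.2-fold higher number from compound 2 to compound 3 (0.35 log units; beyond the scatter) in this assay, so a single fluoro on this ring can shift the read-out toward lower toxicity in this test, though only modestly. With 2-fluorophenyl held in place, the other single change, pyridin-4-yl in place of pyridin-2-yl, gives a 2.0-fold higher number from compound 1 to compound 3 (0.31 log units; beyond the scatter), another modest step, so the form of the pyridine group counts as well. For the compounds shown here, compound 1 and compound 2 differ in two places at once, and their closeness gave no sign of either step, whereas each change can now be read alone, though from only one pair of compounds. Nothing measured here gives a reason for these steps.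

The compounds shown leave open whether the fluoro step would also appear with pyridin-2-yl in place of pyridin-4-yl. They also leave open whether chloro or methoxy in place of the fluoro would move the number in the same direction, or whether the step belongs to fluoro alone.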